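Notes on a stereoisomer of compound 1

The source may report more compounds than this note shows. Statements on the series, on what has been measured and on what is new or still open speak of the compounds shown alone.

Compound 1 `CC(C)C[C@@H](NC(=O)OC(C)(C)C)C(=O)N1CCC[C@H]1C(=O)N1[C@H](C(=O)OCc2ccccc2)[C@H]1C(=O)OCc1ccccc1` has no numerical value in a functional assay on J774 cells (Mus musculus) for cytotoxicity, with a stated time of 48 h; on this read-out higher numbers stand for weaker inhibition and lower numbers for stronger inhibition: compound 1 gives > 100000 nM, which is a limit and not a number. Compound 2 `CC(C)(C)OC(=O)NCC(=O)N1CCC[C@H]1C(=O)N1[C@H](C(=O)OCc2ccccc2)[C@H]1C(=O)OCc1ccccc1` gives > 100000 nM, also a limit. Going by the values given here, the series so far therefore rests on (the limit of > 100000 nM in this assay, at which 2 of the 2 values shown sit).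

Compound 3 `CC(C)C[C@H](NC(=O)OC(C)(C)C)C(=O)N1CCC[C@H]1C(=O)N1[C@@H](C(=O)OCc2ccccc2)[C@@H]1C(=O)OCc1ccccc1` is compared with compound 1 as follows: the two compounds have the same atoms and bonds and differ only in configuration as drawn: 3 of 4 stereo elements differ; a stereocentre at a saturated chain carbon is drawn R in compound 1 and S in compound 3; a stereocentre at a saturated ring carbon is drawn S in compound 1 and R in compound 3; a stereocentre at a saturated ring carbon is drawn S in compound 1 and R in compound 3. The two compounds have the same atoms and bonds, and the stereocentre at the saturated chain carbon and both stereocentres at saturated ring carbons are drawn the other way round.

Among the compounds with values here, the only measured step, a step that the two limits leave unreadable from compound 1 to compound 2, puts hydrogen in place of isobutyl on a saturated chain carbon. It concerns a group and not configuration, and it offers no size to carry over. Within the data shown here, no measured pair isolates configuration, so no step beyond the scatter, and no direction, is expected in this assay. The estimated step is a number no higher from compound 1 to compound 3 (the limit leaves the size open). The estimate for compound 3 is 100000 nM, with an expected range of 40000 nM to 250000 nM.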

Compound 3, half-maximal inhibitory concentration: > 125000 nM
Compound 3 was reported as a limit; the forecaster's own chance of this, stated with the estimate: 85%; at least 1.2-fold (0.09 log units) between middle value and limit.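

In this assay compound 3 gives > 125000 nM, which is a limit and not a number. Going by these compounds alone, compound 1 also has only a limit, so no step between compound 1 and compound 3 can be read. The compounds shown leave open whether the configuration as drawn alters cytotoxicity in this assay at all.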